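From a Nitrophenyl Ketone to a Difluorophenyl Analogue

This account rests on a few compounds, and the source may have more. Where it says the series, first, only, none or still open, it means among the compounds named here.

The series rests on a shared core bearing a ketone. Compound 1 `CC1(C)C=C(n2ccccc2=O)c2cc(C(=O)c3cccs3)ccc2O1` carries a thiophen-2-yl group on that carbonyl carbon, while compound 2 `CC1(C)C=C(n2ccccc2=O)c2cc(C(=O)c3ccccc3[N+](=O)[O-])ccc2O1` carries a 2-nitrophenyl group in the same place. In a functional assay (trachea) with Rattus norvegicus as the target (on this read-out higher numbers stand for higher potency (the scale is a negative logarithm) and lower numbers for lower potency), compound 1 gives 5.84 and compound 2 gives 5.64. Among the measured compounds shown here, compound 2 thus stands at the lower of the two numbers so far, but the step of a number 0.20 log units lower from compound 1 to compound 2 (within the scatter) is within the scatter, so the two cannot be told apart on this read-out.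

Compound 3 `CC1(C)C=C(n2ccccc2=O)c2cc(C(=O)c3c(F)cccc3F)ccc2O1` is the next variation on the same carbonyl carbon: 2,6-difluorophenyl in place of 2-nitrophenyl on a carbonyl carbon. For the measured compounds named here, the only measured step that bears on this change is the one at the same position, a number 0.20 log units lower from compound 1 to compound 2 (within the scatter), which stayed within the scatter when one aromatic group replaced another on the carbonyl. The step expected for compound 3 is therefore a number 0.11 log units higher from compound 2 to compound 3 (within the scatter), in no particular direction and not beyond the scatter. Compound 3 is estimated at 5.75, with a likely range from 5.35 to 6.15.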

Compound 3, logarithm of the reciprocal of the active concentration, log(1/C): 5.99
Compound 3: middle estimate off by 0.24 log units, on the low side; low and high end bracket the measured number.
By their numbers in this assay, from the lowest: compounds 2, 1 and 3 (each within the scatter of the next, the first and the last beyond it).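

In this assay, among the compounds shown here, the group on this carbonyl carbon now gives a step beyond the scatter, though a modest one (a number 0.35 log units higher from compound 2 to compound 3 (beyond the scatter)), whereas the first exchange at this place could not be told from repeat-measurement noise. The comparison with the thiophen-2-yl group gives a different answer (a number 0.15 log units higher from compound 1 to compound 3 (within the scatter)), so 2,6-difluorophenyl is separated from 2-nitrophenyl but not from thiophen-2-yl, and the only readable difference among the three compounds lies between compound 2 and compound 3. No supporting measurement is available to explain this difference.

The three compounds leave open whether the step from 2-nitrophenyl to 2,6-difluorophenyl belongs to the loss of the nitro group, to the arrival of the two fluorines, or to both, and a plain phenyl group on the same carbonyl carbon would help to separate these. It also remains open how far this place tolerates groups of another kind, such as a cyclohexyl ring or a short alkyl chain, as all three compounds shown carry an aromatic ring there.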